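The source may report more compounds than this note shows. Statements on the series, on what has been measured and on what is new or still open speak of the compounds shown alone.

In a functional assay (lung) for inhibition, with Cavia porcellus as the target (on this read-out higher numbers stand for weaker inhibition and lower numbers for stronger inhibition), compound 3 (`CCCC(CCc1nnn[nH]1)Cc1ccc(OCc2ccc3ccccc3n2)cc1`) gives 32 nM. This places it within the scatter of compound 2 (`CC(CCc1nnn[nH]1)Cc1ccc(OCc2ccc3ccccc3n2)cc1`), which gives 27 nM. Compound 1 (`O=C(O)CCC(Cc1ccc(OCc2ccc3ccccc3n2)cc1)c1ccccc1`) gives 65 nM, a higher number than compound 3 by more than the scatter, and so a weaker inhibition.

The next compound to be tested is compound 4 (`c1ccc(C(CCc2nnn[nH]2)Cc2ccc(OCc3ccc4ccccc4n3)cc2)cc1`). It differs from compound 3 as follows: phenyl in place of propyl on a saturated chain carbon bound to two saturated chain carbons. In words, it has phenyl in place of propyl on a saturated chain carbon bound to two saturated chain carbons.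

Within the data shown here, only one measured step bears directly on this change: a 1.2-fold higher number from compound 2 to compound 3 (0.07 log units; within the scatter). That step puts ethyl in place of hydrogen on a saturated chain carbon, and it stays within the scatter. It shows tolerance for a larger chain group but says nothing about a ring. Among the measured compounds shown here, compound 1 also carries phenyl, and its 65 nM hints that the number may drift upward, though it differs from compound 4 elsewhere too, so no measured step isolates phenyl.

No change beyond the scatter is therefore expected, with only a slight lean toward a higher number. The expected change is a 1.3-fold higher number from compound 3 to compound 4 (0.10 log units; within the scatter). For compound 4 the estimated value is 40 nM, with an expected range from 18 nM to 90 nM.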

Compound 4, half-maximal inhibitory concentration: 14 nM
Beside the measured number, compound 4's estimate is 2.9-fold (0.46 log units) above it, outside the stated range (below it).
By their numbers in this assay, from the lowest: compounds 4, 2 and 3 (each within the scatter of the next, the first and the last beyond it); then compound 1.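

In this assay, among these compounds, the saturated chain carbon bound to two saturated chain carbons takes a ring as well as an open chain: phenyl in place of propyl gives a 2.3-fold lower number from compound 3 to compound 4 (0.36 log units; beyond the scatter), the first change at this carbon to pass the scatter, while phenyl in place of methyl gives a 1.9-fold lower number from compound 2 to compound 4 (0.29 log units; within the scatter) and stays within it. With phenyl present on both sides, 1H-tetrazol-5-yl in place of carboxy gives a 4.6-fold lower number from compound 1 to compound 4 (0.67 log units; beyond the scatter), so the higher number of compound 1 does not carry over to phenyl once the tetrazole stands at the end of the chain. Nothing available here accounts for either change.

How cyclohexyl or a pyridine ring on this carbon would compare with phenyl remains open, so the compounds shown do not separate the presence of a ring from its aromatic character or its size. From the compounds shown here alone, it also remains open how a carboxylic acid in place of the tetrazole would behave with methyl or propyl on this carbon, and whether a substituted phenyl or a benzyl group would lower the number further.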